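Replacing a four-membered ring amide with cyanomethyl

The source may hold more compounds than are shown below. What is called first, only, known or untested is meant among the compounds shown, and "the series" means these compounds.

Compound 3 `O=C(NCCSc1nonc1/C(=N/O)Nc1ccc(F)c(C(F)F)c1)C1CS(=O)(=O)C1` stands at the limit of an ADME assay on isolated protein for pharmacokinetics, with UDP-glucuronosyltransferase 1A9 (Homo sapiens) as the target, read by LC-MS, with a stated time of 60 min, at 37 degrees C, tested at 1 uM, in the presence of a further agent that is not named here; on this read-out lower numbers stand for a shorter-lived compound and higher numbers for a longer-lived compound: in this assay compound 3 gives > 3 h, a limit and not a number. Compound 1 `NS(=O)(=O)CC(=O)NCCSc1nonc1/C(=N/O)Nc1ccc(F)c(C(F)F)c1` gives > 3 h, likewise a limit. Compound 2 `CC1(C(=O)NCCSc2nonc2/C(=N/O)Nc2ccc(F)c(C(F)F)c2)CCN1` gives > 3 h, again a limit. The steps a step that the two limits leave unreadable from compound 1 to compound 2, a step that the two limits leave unreadable from compound 1 to compound 3 and a step that the two limits leave unreadable from compound 2 to compound 3 therefore cannot be sized; what the data show is the limit of > 3 h in this assay, at which 3 of the 3 values shown sit. Compound 4 `N#CCC(=O)NCCSc1nonc1/C(=N/O)Nc1ccc(F)c(C(F)F)c1` differs from compound 3 by a group of 3 heavy atoms (2 carbon, 1 nitrogen; no ring) in place of a group of 6 heavy atoms (3 carbon, 2 oxygen, 1 sulfur; one four-membered non-aromatic ring with 1 hetero atom), on a carbonyl carbon. The measured steps bear on this change only in that none of them dropped below the limit, so compound 4 is expected to remain long-lived, with an expected step of a number no higher from compound 3 to compound 4 (the limit leaves the size open). The half-life of compound 4 is estimated at 3 h, between 1.5 h and 6 h.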

Compound 4, half-life: 1.73 h
For compound 4 the middle estimate is 1.7-fold (0.24 log units) above the measured one; measured number inside the range.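

In this assay, going by these compounds alone, compound 4, with cyanomethyl on the carbonyl carbon, is the only compound here that gives a number and not a limit: the limit of > 3 h in this assay, at which 3 of the 4 values shown sit. Within the data shown here, its steps can therefore be bounded for the first time, as an at least 1.7-fold lower number from compound 3 to compound 4 (0.23 log units; that floor lies within the scatter), an at least 1.7-fold lower number from compound 2 to compound 4 (0.23 log units; that floor lies within the scatter) and an at least 1.7-fold lower number from compound 1 to compound 4 (0.23 log units; that floor lies within the scatter). Each floor lies within the scatter, so the real size of these steps remains unsettled.

As far as these compounds go, how long compound 1, compound 2 and compound 3 actually last remains open. So does what an amine or a carboxylic acid on the carbonyl carbon would give in this assay.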